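Ring size at the saturated carbon: from compound 3 to compound 4

The source may report more compounds than this note shows. Statements on the series, on what has been measured and on what is new or still open speak of the compounds shown alone.

The series shares one core, carried by compound 1 `Cc1nn([C@H](C)c2ccc(Cl)cc2Cl)c2nc(N3CC[C@H](N4CCCC4)[C@H](C)C3)cnc12`, compound 2 `Cc1nn([C@H](C)c2ccc(Cl)cc2Cl)c2nc(N3CC[C@H](N4CCC4)[C@H](C)C3)cnc12`, compound 3 `Cc1nn([C@H](C)c2ccc(Cl)cc2Cl)c2nc(N3CC[C@H](N4CCC[C@H]4CCS(C)(=O)=O)[C@H](C)C3)cnc12` and the yet unmeasured compound 4 `Cc1nn([C@H](C)c2ccc(Cl)cc2Cl)c2nc(N3CC[C@H](N4CCCCC4)[C@H](C)C3)cnc12`. In an assay on CCRF-CEM cells for antagonist activity at C-C chemokine receptor type 4 (Homo sapiens), read by CellTiter-Glo, with stated times of 30 min and 60 min, in the presence of a further agent that is not named here (on this read-out higher numbers stand for weaker inhibition and lower numbers for stronger inhibition), compound 2 gives 218 nM. In this assay compound 1 gives "not determined" (no result reported), and compound 3 likewise gives "not determined" (no result reported), so compound 3 stands without a number and cannot be placed against compound 2. The change from compound 3 to compound 4 is piperidin-1-yl in place of 2-(2-(methylsulfonyl)ethyl)pyrrolidin-1-yl on a saturated ring carbon. Going by the values given here, no measured pair in this set shows what such a change does, so the direction of the step remains open. Among the compounds with values here, on the sole number available, that of compound 2 in this assay, compound 4 is expected to land close by, within the scatter of repeated measurements rather than beyond it. Compound 4 is therefore estimated at 200 nM in this assay, with a range from 50 nM to 800 nM.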

Compound 4, half-maximal inhibitory concentration: 361 nM
Beside the measured number, compound 4's estimate is 1.8-fold (0.26 log units) below it; measured number inside the range.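

In this assay, this saturated ring carbon now has its first readable comparison, with piperidin-1-yl in place of azetidin-1-yl giving a 1.7-fold higher number from compound 2 to compound 4 (0.22 log units; within the scatter) between two simple cyclic amines. On this single pair, the read-out does not separate the two ring sizes, and the six-membered non-aromatic ring keeps the number in the same range as the smaller ring. Nothing measured here accounts for this result.

Compound 1 and compound 3 carry no number, so steps to them cannot be read, and 2-(2-(methylsulfonyl)ethyl)pyrrolidin-1-yl stays unplaced against the two simple rings. Also open, from the compounds shown here alone, is whether an open-chain amine such as dimethylamino, or a morpholin-4-yl ring, would stay in this range on the same carbon.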